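From Compound 2 to Its Hydroxy Relative, Compound 3

A few compounds are considered here, and "the series" means these few. Any claim that something is new, unique, unknown or untested is made for them only; others in the source may bear on it.

Measured in a functional assay on T47D cells (Homo sapiens) for antiproliferative activity, read by MTT assay, with a stated time of 72 h; a lower number here means a stronger inhibitor, a higher number a weaker inhibitor:
- compound 1 `CCn1ccnc1-c1cc(OC)c(OC)c(OC)c1`: > 100000 nM (a limit of the assay)
- compound 2 `COc1ccc(-n2ccnc2-c2cc(OC)c(OC)c(OC)c2)cc1`: 1400 nM

Compound 1 gives > 100000 nM as its result, and this is a limit and not a number. Within the data shown here, compound 2 gives 1400 nM as the only actual number so far, so it cannot yet be ranked against any other number. Among the measured compounds shown here, the one measured step is an at least 71-fold lower number from compound 1 to compound 2 (1.85 log units; beyond the scatter) and it is large and beyond the scatter, with 4-methoxyphenyl in place of ethyl on an aromatic nitrogen.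

Compound 3 `COc1ccc(-n2ccnc2-c2cc(OC)c(OC)c(OC)c2)cc1O` keeps that 4-methoxyphenyl group and adds a single change hydroxy in place of hydrogen on an aromatic carbon with hydroxy in place of hydrogen on an aromatic carbon. For the measured compounds named here, the step of an at least 71-fold lower number from compound 1 to compound 2 (1.85 log units; beyond the scatter) is the only guide, and it concerns another place, so it shows only that this part of compound 2 can move the number strongly. A moderate step toward a lower number in this assay is therefore expected, though with wide uncertainty. The expected change is a 7.0-fold lower number from compound 2 to compound 3 (0.85 log units; beyond the scatter) on this estimate. For compound 3 the estimated value is 200 nM with an expected range from 10 nM to 2500 nM around it.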

Compound 3, half-maximal inhibitory concentration: 53100 nM
Compound 3: middle estimate off by 270-fold (2.42 log units), on the low side, and the stated range ends below it.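

In this assay, hydroxy in place of hydrogen on an aromatic carbon, ortho to a methoxy group and meta to a large group, gives a 38-fold higher number from compound 2 to compound 3 (1.58 log units; beyond the scatter), so this position on the 4-methoxyphenyl group does not accept the change without a large penalty. Among these compounds, the only earlier step, an at least 71-fold lower number from compound 1 to compound 2 (1.85 log units; beyond the scatter), concerned the whole group on the aromatic nitrogen, while the new step shows that a small change within that group also moves the number strongly, this time toward a weaker inhibitor. Compound 1 alone remains at a limit of the assay, and compound 3 still gives a real number, so this step has a measured size: the limit of > 100000 nM in this assay, at which 1 of the 3 values shown sits.

The compounds shown leave open whether this loss belongs to the hydroxy group itself or would follow any group at this place, such as a fluorine atom, an amine or a longer chain like ethoxy. They also leave open whether a hydroxy group on another carbon of the same ring would bring a step of similar size, or whether replacing the methoxy group with it would do so.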